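The compounds below may be only part of what the source reports. "The series", "measured", "known", "first", "only" and "open" are said of these compounds alone.

Among the measured compounds shown here, in an ADME assay on the whole organism (Mus musculus, strain CD-1) for pharmacokinetics (on this read-out lower numbers stand for slow clearance and higher numbers for fast clearance), compound 1 (`CCOc1cc([C@](O)(CCN(C)C)[C@@H](c2cc3cc(Br)ccc3nc2OC)c2cccc(OC)c2F)cc(OC)n1`) gives 19 mL/min/kg and compound 2 (`COc1cc([C@](O)(CCN(C)C)[C@@H](c2cc3cc(Br)ccc3nc2OC)c2cccc(OC)c2F)cc(SC)n1`) gives 13 mL/min/kg, so compound 2 stands within the scatter of the only other measured compound. For the measured compounds named here, the single measured step, a 1.5-fold lower number from compound 1 to compound 2 (0.16 log units; within the scatter), is methylsulfanyl in place of ethoxy on an aromatic carbon, and it stays within the scatter. Compound 3 (`COc1cc([C@](O)(CCN(C)C)[C@@H](c2cc3cc(C#N)ccc3nc2OC)c2cccc(OC)c2F)cc(SC)n1`) keeps the methylsulfanyl group of compound 2 but carries cyano in place of bromo on an aromatic carbon. Going by the values given here, no measured pair changes that place, so the one measured step bears on it only indirectly and gives no direct guide to its size. No step beyond the scatter is therefore expected in this assay, and this expectation is a loose one. The expected step is a 1.2-fold higher number from compound 2 to compound 3 (0.06 log units; within the scatter). For compound 3 the estimated clearance is 15 mL/min/kg, with an expected range of 7 mL/min/kg to 32 mL/min/kg.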

Compound 3, clearance: 42 mL/min/kg
Compound 3: the middle estimate sits 2.8-fold (0.45 log units) below what was measured; the measured number lies above the stated range.
By their numbers in this assay, from the lowest: compounds 2 and 1 (each within the scatter of the next); then compound 3.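

In this assay, cyano in place of bromo on an aromatic carbon of the six-membered aromatic ring of carbon only gives a 3.2-fold higher number from compound 2 to compound 3 (0.51 log units; beyond the scatter), a modest step that lies beyond the scatter. This place therefore affects the read-out in a way the earlier comparison could not show: that comparison, a 1.5-fold lower number from compound 1 to compound 2 (0.16 log units; within the scatter), concerns a different place and stays within the scatter. Nothing on hand accounts for the size or direction of this step.

Since this is the only pair shown that changes this place, how chloro, methyl or a primary amide would compare there remains open. On these data alone, it is also open whether the same change from bromo to cyano would give a similar step with ethoxy in place of methylsulfanyl.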